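The source may hold more compounds than are shown below. What is called first, only, known or untested is meant among the compounds shown, and "the series" means these compounds.

Compound 1 `CCc1nc(N)nc2c1c(-c1ccc3oc(N)nc3c1)nn2C(C)C` gives in an ADME assay on cells (Hepatocyte, Homo sapiens) for metabolic stability, read by LC-MS, with a stated time of 90 min, tested at 1 uM (on this read-out higher numbers stand for fast clearance and lower numbers for slow clearance), a reading of < 5 uL/min, which is a limit of the assay and not a number.
Compound 2 `CC(C)n1nc(-c2ccc3oc(N)nc3c2)c2c(CO)nc(N)nc21` gives in this assay a reading of < 5 uL/min, again a limit rather than a number.
Compound 3 `CC(C)n1nc(-c2ccc3oc(N)nc3c2)c2c(=O)[nH]c(N)nc21` gives in this assay a reading of < 5 uL/min, also a limit.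

All three readings sit at the limit of < 5 uL/min in this assay, at which 3 of the 3 values shown sit, so compound 3 cannot be placed relative to the others on the numbers shown. Among the compounds with values here, the only measured single change, a step that the two limits leave unreadable from compound 1 to compound 2, is unreadable as well, both of its ends being limits. Compound 4 `CC(C)n1nc(-c2ccc3oc(N)nc3c2)c2c(=O)[nH]c(N(C)C)nc21` differs from compound 3 by dimethylamino in place of amino on an aromatic carbon. Within the data shown here, no measured step shows what dimethylamino in place of amino does here, so no direction can be read off from the measured compounds. With every measured compound at the limit, compound 4 is expected to stay near it too, which means a step of a number no lower from compound 3 to compound 4 (the limit leaves the size open) that is expected to lie within the scatter. The estimate for compound 4 in this assay is 5 uL/min, with a range from 2 uL/min to 15 uL/min, and a sizeable chance that only a limit is reported.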

Compound 4, intrinsic clearance in a liver preparation (reported as CLH), per the amount of preparation that the assay uses in the Hepatocyte assay: < 5 uL/min
Compound 4: no number, only a limit; the forecaster's own chance of this, stated with the estimate: 55%; the middle value sits exactly at the limit.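

In the Hepatocyte assay compound 3 and compound 4 both give only a limit, and the step between them cannot be read. In a physicochemical assay for solubility, read by HPLC, in phosphate buffer, measured as kinetic solubility, with a stated time of 24 h, at 20 degrees C, at pH 7.4, tested at 100 uM (on this read-out lower numbers stand for lower solubility and higher numbers for higher solubility), compound 3 gives 9200 nM and compound 4 gives 2000 nM, which is a 4.6-fold lower number from compound 3 to compound 4 (0.66 log units; beyond the scatter). The compounds shown leave open whether any change to the shared core moves the reading in the Hepatocyte assay off its limit.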